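Adding a Hydroxy Group: Expected Paw Edema Inhibition

The compounds below may be only part of what the source reports. "The series", "measured", "known", "first", "only" and "open" are said of these compounds alone.

Three compounds were tested in a functional assay on the whole organism (strain Charles-Foster albino) for inhibition, with Rattus norvegicus as the target, read by paw edema, at a dose of 50 mg/kg by the oral route; a lower number here means less inhibition, a higher number more inhibition at the dose given (going by the name of the read-out). Compound 1 `O=c1c2cc(Br)ccc2nc(CSc2nnc(-c3ccncc3)o2)n1/N=C/c1ccccc1` gives 19.4%. Compound 2 `O=c1c2cc(Br)ccc2nc(CSc2nnc(-c3ccncc3)o2)n1/N=C/c1ccc(O)cc1` gives 22.3%, and compound 3 `O=c1c2ccccc2nc(CSc2nnc(-c3ccncc3)o2)n1/N=C/c1ccccc1` gives 16.3% in this assay. The three numbers lie within the scatter of one another.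

From compound 1 to compound 2 the change is hydroxy in place of hydrogen on an aromatic carbon, and the step was a number 2.9 percentage points higher from compound 1 to compound 2 (within the scatter). Compound 3 differs from compound 1 in its core: hydrogen in place of bromo on an aromatic carbon, with a step of a number 3.1 percentage points lower from compound 1 to compound 3 (within the scatter).

Compound 4 `O=c1c2ccccc2nc(CSc2nnc(-c3ccncc3)o2)n1/N=C/c1ccc(O)cc1` has not yet been measured. It differs from compound 3 by hydroxy in place of hydrogen on an aromatic carbon, which is the same change as that from compound 1 to compound 2, at a place described in the same words. The expectation for compound 4 therefore rests on compound 2, whose step from compound 1 was a number 2.9 percentage points higher from compound 1 to compound 2 (within the scatter). Resting on that step, compound 4 is expected to show a number 2.7 percentage points higher from compound 3 to compound 4 (within the scatter) in this assay, a small step within the scatter. Compound 4 is accordingly estimated at 19%, with a likely range from 12% to 27%.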

Compound 4, a percentage reported as inhibition, in the whole organism at one dose (the size of the read-out at that dose, not a potency): 18.2%
Compound 4: middle estimate off by 0.8 percentage points, on the high side; the measured number falls inside the stated range.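

In this assay, within the data shown here, hydroxy in place of hydrogen on the core without bromo gave a number 1.9 percentage points higher from compound 3 to compound 4 (within the scatter), and the two hydroxy steps do not differ beyond what repeated measurements would allow: the same change on two cores in this assay, a number 2.9 percentage points higher (within the scatter) from compound 1 to compound 2 and a number 1.9 percentage points higher (within the scatter) from compound 3 to compound 4, 1 percentage points apart, within the scatter of two such steps Hydrogen in place of bromo, read on the hydroxy-bearing pair, gave a number 4.1 percentage points lower from compound 2 to compound 4 (within the scatter), and this step likewise agrees with its earlier counterpart: the same change on two cores in this assay, a number 3.1 percentage points lower (within the scatter) from compound 1 to compound 3 and a number 4.1 percentage points lower (within the scatter) from compound 2 to compound 4, 1 percentage points apart, within the scatter of two such steps Every one of these steps lies within the scatter, so the agreement shows only that neither change produced a clear shift on either core; it does not show that the hydroxy or the bromo has a real effect that carries from one core to another.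

The compounds shown leave open whether another group in place of the 4-hydroxy on the phenyl, such as an amine or a carboxylic acid, would give a step beyond the scatter. They also leave open whether the same change would behave alike on cores other than these two.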